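A few compounds are considered here, and "the series" means these few. Any claim that something is new, unique, unknown or untested is made for them only; others in the source may bear on it.

The compounds share one core and differ only in the aromatic group attached to it. Compound 1 `CCOC(=O)C1=Cc2ccccc2OC1(OCc1cc(-c2ccc(F)cc2F)no1)C(F)(F)F` carries a 2,4-difluorophenyl and compound 3 `CCOC(=O)C1=Cc2ccccc2OC1(OCc1cc(-c2ccc(Br)cc2)no1)C(F)(F)F` a 4-bromophenyl. In a functional assay on A549 cells (Homo sapiens) for inhibition, read by MTT assay, with a stated time of 24 h (on this read-out higher numbers stand for weaker inhibition and lower numbers for stronger inhibition), compound 1 gives only a limit of the assay, > 150000 nM. Compound 3 likewise gives only a limit, > 150000 nM. The step that the two limits leave unreadable from compound 1 to compound 3 therefore cannot be read. Compound 2 `CCOC(=O)C1=Cc2ccccc2OC1(OCc1cn(-c2cccc(OC)c2)nn1)C(F)(F)F` bears a 3-methoxyphenyl on an aromatic nitrogen; in this assay compound 2 also gives only a limit, > 150000 nM, so where compound 2 stands is known only through (the limit of > 150000 nM in this assay, at which 3 of the 3 values shown sit). Compound 4 `CCOC(=O)C1=Cc2ccccc2OC1(OCc1cn(-c2ccc(C)cc2)nn1)C(F)(F)F` differs from compound 2 by 4-methylphenyl in place of 3-methoxyphenyl on an aromatic nitrogen. Among the compounds with values here, no measured step resembles this change, and the single step available is unreadable, so neither direction nor size can be drawn from the measurements. The expected step that the limit leaves unreadable from compound 2 to compound 4 is therefore none that the scatter could reveal. Compound 4 is expected to give 200000 nM, with a range from 100000 nM to 600000 nM, most probably again reported only as a limit.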

Compound 4, half-maximal inhibitory concentration: 19700 nM
Beside the measured number, compound 4's estimate is 10-fold (1.01 log units) above it; the measured number lies below the stated range.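

At this place on an aromatic nitrogen, the choice of aromatic group can move the read-out in this assay: 4-methylphenyl in place of 3-methoxyphenyl gives an at least 7.6-fold lower number from compound 2 to compound 4 (0.88 log units; beyond the scatter). Compound 4 is the only compound shown with a number rather than a limit: the limit of > 150000 nM in this assay, at which 3 of the 4 values shown sit. The other steps shown cannot be read, so this single pair is the only measured evidence of a change in this series.

The pair changes both the group and its place on the phenyl ring, so it leaves open whether the methyl group, the loss of the methoxy group or the new place matters. A 3-methylphenyl or a 4-methoxyphenyl on the same nitrogen would separate these, and a 4-aminophenyl or a longer 4-alkyl chain would show how far the trend extends.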